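Hydroxyphenyl for Chlorophenyl: Expecting a Cytotoxicity Number

The source may report more compounds than this note shows. Statements on the series, on what has been measured and on what is new or still open speak of the compounds shown alone.

Measured so far:
compound 1 `Fc1cccc(-c2nc(Nc3ccccc3)c3ccccc3n2)c1`: > 50000 nM
compound 2 `Fc1cccc(-c2nc(Nc3ccc(Cl)cc3)c3cc(F)ccc3n2)c1`: 38400 nM
compound 3 `Fc1cccc(-c2nc(Nc3cccc(Cl)c3)c3cc(F)ccc3n2)c1`: > 50000 nM

For the measured compounds named here, in a functional assay on U2OS cells (Homo sapiens) for cytotoxicity, read by MTT assay, with a stated time of 48 h (on this read-out higher numbers stand for weaker inhibition and lower numbers for stronger inhibition), compound 2 gives 38400 nM, the only true number among the three. Compound 1 gives a limit of the assay, > 50000 nM. Compound 3 likewise gives a limit, > 50000 nM. Compound 4 `Oc1ccccc1Nc1nc(-c2cccc(F)c2)nc2ccc(F)cc12` is not yet measured; it differs from compound 2 by 2-hydroxyphenyl in place of 4-chlorophenyl on a nitrogen on an aromatic ring. Going by the values given here, the only measured step on the same nitrogen is an at least 1.3-fold higher number from compound 2 to compound 3 (0.11 log units; that floor lies within the scatter), which moved the value to the limit (the limit of > 50000 nM in this assay, at which 2 of the 3 values shown sit). With two of three values at that limit and a weak starting point, compound 4 is expected to sit near the limit, with a step of a 1.3-fold higher number from compound 2 to compound 4 (0.11 log units; within the scatter). Compound 4 is therefore estimated at 50000 nM, within 15000 nM to 160000 nM.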

Compound 4, half-maximal inhibitory concentration: 41400 nM
For compound 4 the middle estimate is 1.2-fold (0.08 log units) above the measured one; the range from low to high includes it.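

In this assay, 2-hydroxyphenyl replacing 4-chlorophenyl on this nitrogen gives a 1.1-fold higher number from compound 2 to compound 4 (0.03 log units; within the scatter). A ring with a hydrogen-bond donor and no chlorine therefore still gives a true number, and at this weak level the two groups cannot be told apart. The change from 3-chlorophenyl gives an at least 1.2-fold lower number from compound 3 to compound 4 (0.08 log units; that floor lies within the scatter), and its size stays uncertain because compound 3 stands at a limit: the limit of > 50000 nM in this assay, at which 2 of the 4 values shown sit.

On these data alone, what an aminophenyl or carboxyphenyl group on this nitrogen would give stays open. So does whether any group here can reach values well clear of that limit.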